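Sulfonamide series on colon cells: methoxy for phenyl

This account rests on a few compounds, and the source may have more. Where it says the series, first, only, none or still open, it means among the compounds named here.

Measured so far, in a functional assay on HT-29 cells (Homo sapiens) for inhibition, read by MTT assay, with a stated time of 72 h; a higher number here means a weaker inhibitor of growth, a lower number a stronger inhibitor of growth:
compound 1 `CC(C)(C)c1ccc(CNCCCNS(=O)(=O)c2cc(C(F)(F)F)cc(C(F)(F)F)c2)cc1` gives 2000 nM
compound 2 `O=S(=O)(NCCCNCC1COc2ccccc2O1)c1cc(C(F)(F)F)cc(C(F)(F)F)c1` gives 2200 nM
compound 3 `O=S(=O)(NCCCNCc1ccc(-c2ccccc2)cc1)c1cc(C(F)(F)F)cc(C(F)(F)F)c1` gives 2300 nM

All three compounds share the shared core and differ only in the group carried at the far end of the chain. Compound 3 has the highest number of the three, but its gap to compound 2 and to compound 1 lies within the scatter, so no order among them is established. The two steps that have been followed, a 1.1-fold higher number from compound 1 to compound 2 (0.04 log units; within the scatter) and a 1.2-fold higher number from compound 1 to compound 3 (0.06 log units; within the scatter), both stay within the scatter: replacing the end group in this series has so far left the growth inhibition essentially unchanged.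

The next compound, compound 4 `COc1ccc(CNCCCNS(=O)(=O)c2cc(C(F)(F)F)cc(C(F)(F)F)c2)cc1`, differs from compound 3 by methoxy in place of phenyl on an aromatic carbon. Within the data shown here, no measured pair shows exactly this exchange. The bearing of the two known steps is indirect: they show that a smaller or a differently shaped end group, whether the bicyclic group of compound 2 or the tert-butyl of compound 1, gives a number close to that of compound 3. On this basis compound 4 is expected to stay near compound 3, with a 1.0-fold higher number from compound 3 to compound 4 (0.02 log units; within the scatter) and no step beyond the scatter in either direction. The estimate for compound 4 in this assay is 2400 nM, expected to fall between 1200 nM and 5000 nM.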

Compound 4, concentration for 50% growth inhibition: 2900 nM
The estimate for compound 4 lay 1.2-fold (0.08 log units) below the measured number; the measured number falls inside the stated range.
By their numbers in this assay, from the lowest: compounds 1, 2, 3 and 4 (each within the scatter of the next).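

In this assay, methoxy in place of phenyl on an aromatic carbon, para to a large group, removes a six-membered aromatic ring of carbon only, takes the group from 6 heavy atoms to 2 and adds a hydrogen-bond acceptor, yet gives only a 1.3-fold higher number from compound 3 to compound 4 (0.10 log units; within the scatter) and so stays within the scatter. Methoxy in place of tert-butyl at this same place gives a 1.5-fold higher number from compound 1 to compound 4 (0.16 log units; within the scatter) and stays within the scatter too, as does the exchange of the bicyclic end group for 4-methoxyphenyl, with a 1.3-fold higher number from compound 2 to compound 4 (0.12 log units; within the scatter), so this position has now carried three different groups without a step beyond the scatter. No measured property of these compounds is available to account for these results.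

The compounds shown leave open whether a carboxylic acid or an amine on this aromatic carbon would give a step beyond the scatter. They also leave open whether a longer chain in place of the present one, or nitrile in place of trifluoromethyl on the shared core, would move the number in this series.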